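This account rests on a few compounds, and the source may have more. Where it says the series, first, only, none or still open, it means among the compounds named here.

Working notes on the series. Compound 1 `COc1ccc(F)cc1CNCCCNc1ccnc2cc(Cc3ccc(C#N)cc3)ccc12` gives 6050 nM in an ADME assay on HepG2 cells (Homo sapiens) for cytotoxicity, read by luminescence, CellTiter-Glo and ATP content, with a stated time of 72 h (on this read-out higher numbers stand for an effect only at larger amounts of compound and lower numbers for an effect already at smaller amounts), and stands second highest of the three numbers, with compound 2 nearest and compound 3 furthest, both within the scatter. Compound 2 `COc1ccc(-c2ccc3c(NCCCNCc4cc(F)ccc4OC)ccnc3c2)cc1` gives 5960 nM and compound 3 `COc1ccc(F)cc1CNCCCNc1ccnc2cc(Oc3ccccc3OC)ccc12` gives 6400 nM. The measured steps, a 1.0-fold lower number from compound 1 to compound 2 (0.01 log units; within the scatter), a 1.1-fold higher number from compound 1 to compound 3 (0.02 log units; within the scatter) and a 1.1-fold higher number from compound 2 to compound 3 (0.03 log units; within the scatter), all change the group on the aromatic carbon and all lie within the scatter. Compound 4 `N#Cc1ccc(Cc2ccc3c(NCCCNCc4ccco4)ccnc3c2)cc1` differs from compound 1 elsewhere: furan-2-yl in place of 5-fluoro-2-methoxyphenyl on a saturated chain carbon bound to an amine nitrogen. Going by the values given here, no measured step touches this position, so the three steps bear on it only indirectly, showing the series flat so far. No step beyond the scatter is expected, a 1.0-fold lower number from compound 1 to compound 4 (0.00 log units; within the scatter). Compound 4 is estimated at 6000 nM, within 3000 nM to 12000 nM.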

Compound 4, half-maximal effective concentration: 7910 nM
Compound 4: the middle estimate sits 1.3-fold (0.12 log units) below what was measured, within the range that was stated.
By their numbers in this assay, from the lowest: compounds 2, 1, 3 and 4 (each within the scatter of the next).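

The step at this position, furan-2-yl in place of 5-fluoro-2-methoxyphenyl on a saturated chain carbon bound to an amine nitrogen, gives a 1.3-fold higher number from compound 1 to compound 4 (0.12 log units; within the scatter) in this assay. The flat picture therefore extends beyond the aromatic carbon: going from 9 heavy atoms to 5 leaves the number within the scatter. Nothing at hand gives a reason for this result.

From the compounds shown here alone, whether a carboxylic acid or a morpholine at this position would hold the number stays open. Also open, going by these compounds, is whether furan-2-yl gives the same result with 4-methoxyphenyl or 2-methoxyphenoxy on the aromatic carbon.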